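Amide partner variations on the carbonyl carbon

The compounds below may be only part of what the source reports. "The series", "measured", "known", "first", "only" and "open" are said of these compounds alone.

Measured compounds, all in an assay on HEK293 cells for displacement of a labelled ligand from NPC1-like intracellular cholesterol transporter 1 (Homo sapiens); a lower number here means a stronger inhibitor, a higher number a weaker inhibitor:
Compound 1 `CC1(C)CC(OC(=O)CN2CN(c3ccccc3)C3(CCN(C(=O)c4ccc(C(C)(C)C)cc4)CC3)C2=O)CC(C)(C)N1` gives 1300 nM.
Compound 2 `CC(C)(C)c1ccc(C(=O)N2CCC3(CC2)C(=O)N(CC(=O)N2CCC(O)CC2)CN3c2ccccc2)cc1` gives 4700 nM.
Compound 3 `CC(C)(C)c1ccc(C(=O)N2CCC3(CC2)C(=O)N(CC(=O)NCNS(C)(=O)=O)CN3c2ccccc2)cc1` gives 3200 nM.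

Compound 3 stands second highest of the three numbers in this assay. Its nearest neighbour is compound 2, with a 1.5-fold lower number from compound 2 to compound 3 (0.17 log units; within the scatter); its furthest is compound 1, with a 2.5-fold higher number from compound 1 to compound 3 (0.39 log units; beyond the scatter).

Compound 4 `CC(C)(C)c1ccc(C(=O)N2CCC3(CC2)C(=O)N(CC(=O)N2CCCCC2CO)CN3c2ccccc2)cc1` differs from compound 3 in one place: 2-(hydroxymethyl)piperidin-1-yl in place of ((methanesulfonamido)methyl)amino on a carbonyl carbon. Among the compounds with values here, the entering group is, like that of compound 2, a six-membered ring amine carrying a hydroxyl, so the steps that bear on this one are a 1.5-fold lower number from compound 2 to compound 3 (0.17 log units; within the scatter), which was within the scatter, and a 3.6-fold higher number from compound 1 to compound 2 (0.56 log units; beyond the scatter), a modest rise. Compound 2 and compound 3 sit together; only compound 1 is set apart. Compound 4 is therefore expected to fall close to compound 2 and compound 3, with no step beyond the scatter, a 1.2-fold higher number from compound 3 to compound 4 (0.07 log units; within the scatter). Compound 4 is estimated at 3800 nM, with a range from 1600 nM to 9000 nM.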

Compound 4, half-maximal inhibitory concentration: 11800 nM
Estimate against measurement, compound 4: 3.1-fold (0.49 log units) below; the whole stated range lies below it.
By their numbers in this assay, from the lowest: compound 1; then compounds 3 and 2 (each within the scatter of the next); then compound 4.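

At this carbonyl carbon in this assay, the two hydroxyl-bearing piperidine partners do not behave as one class: 2-(hydroxymethyl)piperidin-1-yl in place of 4-hydroxypiperidin-1-yl gives a 2.5-fold higher number from compound 2 to compound 4 (0.40 log units; beyond the scatter). The same group gives a 3.7-fold higher number from compound 3 to compound 4 (0.57 log units; beyond the scatter) against ((methanesulfonamido)methyl)amino and a 9.1-fold higher number from compound 1 to compound 4 (0.96 log units; beyond the scatter) against (2,2,6,6-tetramethylpiperidin-4-yl)oxy, the widest step in the set, so this position spans a broader range than the first three compounds indicated. Nothing available here accounts for these steps.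

Open questions are whether unsubstituted piperidin-1-yl or 4-(hydroxymethyl)piperidin-1-yl would fall with compound 2 or with compound 4. Also open, going by these compounds, is whether the lower number of compound 1 follows its ester link or its tetramethylpiperidine ring, which the amide made from 2,2,6,6-tetramethylpiperidin-4-amine would separate.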